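Compound 4: an oxygen-linked aminophenyl analogue of compound 1

The source may report more compounds than this note shows. Statements on the series, on what has been measured and on what is new or still open speak of the compounds shown alone.

Measured in an ADME assay on BaF3 cells (Mus musculus) for antiproliferative activity, read by CellTiter-Glo and CCK-8 assay, with a stated time of 72 h; a higher number here means a weaker inhibitor of growth, a lower number a stronger inhibitor of growth:
Compound 1 `Cc1ccc(Nc2ncc3c(n2)N(C)C(=O)N(c2cc(NC(=O)c4cccc(C(F)(F)F)c4)ccc2C)C3)cc1` gives 8000 nM.
Compound 2 `Cc1ccc(Nc2ncc3c(n2)N(C)C(=O)N(c2cc(NC(=O)c4cccc(C(F)(F)F)c4)ccc2C)C3)cc1N(C)C` gives > 10000 nM, which is a limit of the assay, not a number.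
Compound 3 `Cc1ccc(Nc2ncc3c(n2)N(C)C(=O)N(c2cc(NC(=O)c4cccc(C(F)(F)F)c4)ccc2C)C3)cc1N` gives 440 nM.

Among the numbers shown, compound 1 stands highest; its nearest neighbour is compound 3, reached by an 18-fold lower number from compound 1 to compound 3 (1.26 log units; beyond the scatter). Compound 2 sits at the limit of > 10000 nM in this assay, at which 1 of the 3 values shown sits.

Compound 4 `Cc1ccc(Oc2ncc3c(n2)N(C)C(=O)N(c2cc(NC(=O)c4cccc(C(F)(F)F)c4)ccc2C)C3)cc1N` differs from compound 1 in one place: 3-amino-4-methylphenoxy in place of (4-methylphenyl)amino on an aromatic carbon. For the measured compounds named here, the amino group that enters mirrors the large step of an 18-fold lower number from compound 1 to compound 3 (1.26 log units; beyond the scatter), while the swap of the amino linker for an oxygen linker has no measured counterpart here. A lower number is therefore expected, a 5.3-fold lower number from compound 1 to compound 4 (0.73 log units; beyond the scatter), with wide uncertainty: compound 4 is estimated at 1500 nM, between 300 nM and 8000 nM.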

Compound 4, concentration for 50% growth inhibition: > 10000 nM
Compound 4 gave a limit, no number; the forecaster's own chance of this, stated with the estimate: 10%; at least 6.6-fold (0.82 log units) between middle value and limit.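

In this assay compound 4 gives > 10000 nM, which is a limit of the assay, not a number. With the ring amino group kept, replacing the amino linker with an oxygen linker gives an at least 22-fold higher number from compound 3 to compound 4 (1.35 log units; beyond the scatter), so the amino group does not bring its gain on its own. The change from the parent compound gives an at least 1.2-fold higher number from compound 1 to compound 4 (0.09 log units; that floor lies within the scatter), while the step between compound 2 and compound 4 cannot be read, as both are limits.

Going by these compounds, whether a sulfur atom or a methylene linker here would behave like the oxygen linker or the amino linker stays open.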